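From 3-fluorobenzyl to 4-fluorobenzyl: what to expect

The source may hold more compounds than are shown below. What is called first, only, known or untested is meant among the compounds shown, and "the series" means these compounds.

Compounds tested in a functional assay on a cell-free system (plasma, Oryctolagus cuniculus) for inhibition, with stated times of 5 min, 1 min and 6 min; on this read-out lower numbers stand for stronger inhibition and higher numbers for weaker inhibition:
- compound 1 `CCOC(=O)c1c(C)nc(-c2cccc(C#N)c2)n1OCc1ccccc1`: 5930 nM
- compound 2 `CCOC(=O)c1c(C)nc(-c2cccc(C#N)c2)n1OCc1cccc(F)c1`: 22400 nM
- compound 3 `CCOC(=O)c1c(C)nc(-c2cccc(C#N)c2)n1OCc1ccc(F)cc1`: not yet measured

Of the two measured compounds, compound 2 has the higher number, 22400 nM, and so the weaker inhibition in this assay. Compound 3 has the same atoms joined differently: 4-fluorophenyl in place of 3-fluorophenyl on a saturated chain carbon bound to an oxygen on an aromatic ring. Among the measured compounds shown here, only one measured step bears on this change: a 3.8-fold higher number from compound 1 to compound 2 (0.58 log units; beyond the scatter). There, fluoro replaced hydrogen on an aromatic carbon, and the step was modest but beyond the scatter. For the measured compounds named here, no 4-fluorophenyl compound has been measured, so this is only a rough guide. Still, a modest step towards a lower number is expected, leaving compound 3 near the middle of the two known values. The expected change is a 2.0-fold lower number from compound 2 to compound 3 (0.31 log units; beyond the scatter). For compound 3, the estimate is 11000 nM, with an expected range of 3500 nM to 30000 nM.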

Compound 3, half-maximal inhibitory concentration: 5880 nM
Compound 3: the middle estimate sits 1.9-fold (0.27 log units) above what was measured, and the stated range covers the measured number.
By their numbers in this assay, from the lowest: compounds 3 and 1 (each within the scatter of the next); then compound 2.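

In this assay, shifting the fluorine alone gives a 3.8-fold lower number from compound 2 to compound 3 (0.58 log units; beyond the scatter), so on this benzyl ring the place of the fluorine matters, not only its presence. Fluoro in place of hydrogen now gives a 1.0-fold lower number from compound 1 to compound 3 (0.00 log units; within the scatter), so the earlier step from hydrogen to fluoro does not hold for every place on the ring: among these three compounds, only compound 2 stands apart. Nothing available here explains why 3-fluorobenzyl and 4-fluorobenzyl differ.

Going by these compounds, it remains open whether the same gap would appear with chlorine or a methoxy group, as 3-chlorobenzyl against 4-chlorobenzyl or 3-methoxybenzyl against 4-methoxybenzyl. Also open, on these data alone, is how a longer chain between the oxygen and the ring would behave with 4-fluorophenyl at its end.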